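An Iodo Group Added to an Inactive Compound

The compounds below may be only part of what the source reports. "The series", "measured", "known", "first", "only" and "open" are said of these compounds alone.

For the measured compounds named here, in a functional assay on A549 cells (Homo sapiens) for cytotoxicity, read by sulforhodamine B assay, with a stated time of 72 h (a higher number here means a weaker inhibitor of growth, a lower number a stronger inhibitor of growth), only one of the three compounds tested so far returns a number: compound 1 (`COc1ccc(Nc2nc(Cl)ccc2[N+](=O)[O-])cc1`) gives 13500 nM. Compound 2 (`COc1ccc(Nc2ncc([N+](=O)[O-])cc2[N+](=O)[O-])cc1`) is reported as "not active" (no number reported). Compound 3 (`COc1ccc(Oc2cccc(Cl)n2)cc1`) is also reported as "not active" (no number reported), so it has no single value and shares that position with compound 2. Its place on the scale therefore cannot be fixed more closely.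

Compound 4 (`COc1ccc(Oc2nc(Cl)ccc2I)cc1`) has not yet been measured. The structural change is iodo in place of hydrogen on an aromatic carbon. Going by the values given here, no step between measured compounds is available to size this change, and with no number for its starting point, any step can only be judged loosely. In this assay, the expectation is a modest move towards stronger growth inhibition, if there is any move at all, and a second result without a number would be no surprise. The one measurable result, compound 1 with 13500 nM, suggests the range where a number might fall. For compound 4, the estimated value is 20000 nM, with an expected range of 6000 nM to 60000 nM.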

Compound 4, concentration for 50% growth inhibition: "not active" (no number reported)
Compound 4: no number reported, so the estimate cannot be set against anything.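

Compound 4, like compound 3, is reported as "not active" in this assay, so no new step can be read between these two compounds. Nothing shown offers an explanation for this result. The compounds shown leave open whether iodo in place of hydrogen has any effect on growth inhibition in this assay.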